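This account rests on a few compounds, and the source may have more. Where it says the series, first, only, none or still open, it means among the compounds named here.

Of the compounds shown here, three have so far been measured in a functional assay on HeLa cells (Homo sapiens) for cytotoxicity, read by MTT assay, with a stated time of 72 h; a higher number here means a weaker inhibitor, a lower number a stronger inhibitor. Compound 1 `Cc1cc(C)nc(SCc2cc(=O)c3cc(Cl)ccc3o2)n1` gives only a limit of the assay, > 25000 nM. Compound 2 `Cc1nnc(SCc2coc3ccccc3c2=O)o1` gives 1400 nM. Among the compounds with values here, compound 3 `Cc1cc(C)n2nc(SCc3cc(=O)c4cc(Cl)ccc4o3)nc2n1` likewise gives only a limit, > 25000 nM, so it sits at the limit of > 25000 nM in this assay, at which 2 of the 3 values shown sit, and no step from it to another measured compound can be sized. Compound 4 `Cc1ccc2oc(CSc3nc4nc(C)cc(C)n4n3)cc(=O)c2c1` differs from compound 3 in one place: methyl in place of chloro on an aromatic carbon. Compound 3 offers nothing more than its limit of > 25000 nM to build on. Within the data shown here, with no measured step to rest on, the step from compound 3 to compound 4 is expected to be small, a step that the limit leaves unreadable from compound 3 to compound 4, in no direction beyond the scatter. Compound 4 is therefore estimated at 30000 nM, between 8000 nM and 100000 nM, and most likely again only a limit.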

Compound 4, half-maximal inhibitory concentration: > 25000 nM
Compound 4 gave a limit, no number (the forecaster's own chance of this, stated with the estimate: 75%); the middle value lies beyond the limit too.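

Compound 3 and compound 4 both give only a limit in this assay, so no step can be read between them. The compounds shown leave open whether methyl in place of chloro on an aromatic carbon changes the read-out at all.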